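A longer pyrrolidinyl side chain on a shared core

The compounds below may be only part of what the source reports. "The series", "measured", "known", "first", "only" and "open" are said of these compounds alone.

Going by the values given here, in an ADME assay on L6 cells (Rattus norvegicus) for cytotoxicity, read by resazurin assay, with a stated time of 72 h (a lower number here means a stronger inhibitor, a higher number a weaker inhibitor), compound 1 `CN(C)C12CC(c3ccccc3)C(CN(C(=O)CCN3CCCC3)C1)C(c1ccccc1)C2` gives 11700 nM and compound 2 `CN(C)C12CC(c3ccccc3)C(CN(CCN3CCCC3)C1)C(c1ccccc1)C2` gives 5580 nM, so compound 2 holds the lower of only two numbers so far. Compound 3 `CN(C)C12CC(c3ccccc3)C(CN(CCCN3CCCC3)C1)C(c1ccccc1)C2` carries 3-(pyrrolidin-1-yl)propyl where compound 2 carries 2-(pyrrolidin-1-yl)ethyl. The change is (pyrrolidin-1-yl)methyl in place of pyrrolidin-1-yl on a saturated chain carbon, two bonds along the chain from an amine nitrogen in a ring. Among the compounds with values here, the only measured step, a 2.1-fold lower number from compound 1 to compound 2 (0.32 log units; beyond the scatter), came from replacing (2-(pyrrolidin-1-yl)ethyl)carbonyl with 2-(pyrrolidin-1-yl)ethyl. It altered the same side chain in a different way and was modest, so it offers only loose guidance. The expected change in this assay is small, a 1.2-fold lower number from compound 2 to compound 3 (0.09 log units; within the scatter), and no shift beyond the scatter is anticipated. For compound 3 the estimate is 4500 nM, with an expected range from 1800 nM to 11000 nM.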

Compound 3, half-maximal inhibitory concentration: 1550 nM
Estimate against measurement, compound 3: 2.9-fold (0.46 log units) above; measured number outside the range, below it.
By their numbers in this assay, from the lowest: compound 3; then compound 2; then compound 1.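

In this assay the side chain's length alone matters at this position: with the pyrrolidin-1-yl group kept and one more chain carbon added, the result is a 3.6-fold lower number from compound 2 to compound 3 (0.56 log units; beyond the scatter) and lies beyond the scatter. Compounds 1 and 2 could not show this, as they differ by a carbonyl rather than by chain length. Across the two changes together, the result is a 7.5-fold lower number from compound 1 to compound 3 (0.88 log units; beyond the scatter) and both changes lower the number, but nothing measured here bears on the reason for the shift.

As far as these compounds go, it remains open whether a longer chain, such as 4-(pyrrolidin-1-yl)butyl, would lower the number further or reverse the trend. It is also unclear whether the pyrrolidin-1-yl group itself matters, a question that a piperidin-1-yl or dimethylamino group at the chain end could address.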